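From a Sulfonate to an Ester: What to Expect for Compound 4

The source may report more compounds than this note shows. Statements on the series, on what has been measured and on what is new or still open speak of the compounds shown alone.

Three measured compounds share one core and differ only in the group carried on an oxygen on a saturated carbon. Compound 1 `O=c1cc(N2CCN(CC3CCC(OS(=O)(=O)c4cccnc4)CC3)CC2)sc2c([N+](=O)[O-])cc(C(F)(F)F)cc12` was tested in an ADME assay on Vero cells (Chlorocebus sabaeus) for cytotoxicity, read by MTT assay, with a stated time of 48 h; a lower number here means a stronger inhibitor, a higher number a weaker inhibitor. In this assay compound 1 reaches only a limit of the assay, > 64 ug/mL. Compound 2 `CS(=O)(=O)OC1CCC(CN2CCN(c3cc(=O)c4cc(C(F)(F)F)cc([N+](=O)[O-])c4s3)CC2)CC1` likewise gives only a limit, > 64 ug/mL. Compound 3 `COc1ccccc1C(=O)OC1CCC(CN2CCN(c3cc(=O)c4cc(C(F)(F)F)cc([N+](=O)[O-])c4s3)CC2)CC1` also stands at a limit, > 64 ug/mL. The steps between them therefore cannot be read: a step that the two limits leave unreadable from compound 1 to compound 2, a step that the two limits leave unreadable from compound 1 to compound 3 and a step that the two limits leave unreadable from compound 2 to compound 3.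

Compound 4 `O=C(OC1CCC(CN2CCN(c3cc(=O)c4cc(C(F)(F)F)cc([N+](=O)[O-])c4s3)CC2)CC1)c1ccc2c(c1)OCC2` is not yet measured. It differs from compound 1 in this way: a group of 11 heavy atoms (9 carbon, 2 oxygen; one five-membered non-aromatic ring with 1 hetero atom, one six-membered aromatic ring of carbon only) in place of a group of 9 heavy atoms (5 carbon, 1 nitrogen, 2 oxygen, 1 sulfur; one six-membered aromatic ring with 1 hetero atom), on an oxygen on a saturated carbon. The steps from compound 1 to compound 3 and from compound 2 to compound 3 bear most closely on this change, as they too put a group with a carbonyl on that oxygen, yet both are unreadable. All that is known is the limit of > 64 ug/mL in this assay, at which 3 of the 3 values shown sit. No step beyond the scatter can be expected in this assay; the step that the limit leaves unreadable from compound 1 to compound 4 is expected to be no more than a formality, with another limit the likeliest outcome. Compound 4 is estimated at 100 ug/mL, with a range from 64 ug/mL to 200 ug/mL.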

Compound 4, half-maximal inhibitory concentration: > 64 ug/mL
Compound 4 gave a limit, no number; the forecaster's own chance of this, stated with the estimate: 85%; the middle value lies beyond the limit too.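

No step linking compound 4 with compound 1, compound 2 or compound 3 can be read, because all four compounds stop at the same limit of the assay: the limit of > 64 ug/mL in this assay, at which 4 of the 4 values shown sit.

On these data alone, whether the groups on the oxygen on a saturated carbon differ at all in this assay stays open, with no actual number for any of the four compounds.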